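The source may report more compounds than this note shows. Statements on the series, on what has been measured and on what is new or still open speak of the compounds shown alone.

Measured in a functional assay on SK-BR-3 cells (Homo sapiens) for antiproliferative activity, read by MTT assay, with a stated time of 72 h; on this read-out lower numbers stand for stronger inhibition and higher numbers for weaker inhibition:
Compound 1 `CCN(CC)c1cc(C)c2cc(NC(=O)c3ccc(Cl)c(Cl)c3)ccc2n1` gives 41200 nM
Compound 2 `Cc1cc(NCCN2CCN(C)CC2)nc2ccc(NC(=O)c3ccc(Cl)c(Cl)c3)cc12` gives 2690 nM
Compound 3 `Cc1cc(N2CCCCC2)nc2ccc(NC(=O)c3ccc(Cl)c(Cl)c3)cc12` gives 42500 nM

Compound 3 sits at the high end of these numbers, level with compound 1 (a 1.0-fold higher number from compound 1 to compound 3 (0.01 log units; within the scatter)) and well apart from compound 2. Compound 4 `Cc1cc(NCCN2CCCCC2)nc2ccc(NC(=O)c3ccc(Cl)c(Cl)c3)cc12` carries (2-(piperidin-1-yl)ethyl)amino in place of piperidin-1-yl, next to the ring nitrogen ((2-(piperidin-1-yl)ethyl)amino in place of piperidin-1-yl on an aromatic carbon). Two large steps bear on this, a 15-fold lower number from compound 1 to compound 2 (1.19 log units; beyond the scatter) and a 16-fold higher number from compound 2 to compound 3 (1.20 log units; beyond the scatter), each tied to the (2-(4-methylpiperazin-1-yl)ethyl)amino group of compound 2. Going by the values given here, no measured pair compares piperidin-1-yl with 4-methylpiperazin-1-yl on such a chain. A large step to a lower number is therefore expected in this assay (a 12-fold lower number from compound 3 to compound 4 (1.08 log units; beyond the scatter)). For compound 4 the estimated value is 3500 nM, with 1200 nM to 10000 nM as the expected range.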

Compound 4, half-maximal inhibitory concentration: 1800 nM
Compound 4: the middle estimate sits 1.9-fold (0.29 log units) above what was measured, and the stated range covers the measured number.
By their numbers in this assay, from the lowest: compounds 4 and 2 (each within the scatter of the next); then compounds 1 and 3 (each within the scatter of the next).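

In this assay, (2-(piperidin-1-yl)ethyl)amino on this aromatic carbon next to the ring nitrogen gives large drops against both piperidin-1-yl (a 24-fold lower number from compound 3 to compound 4 (1.37 log units; beyond the scatter)) and diethylamino (a 23-fold lower number from compound 1 to compound 4 (1.36 log units; beyond the scatter)), so the low number of compound 2 does not require a 4-methylpiperazin-1-yl end group. On the chain, piperidin-1-yl and 4-methylpiperazin-1-yl are not told apart (a 1.5-fold lower number from compound 2 to compound 4 (0.17 log units; within the scatter)), the step being within the scatter. No supporting data on hand account for these steps. As far as these compounds go, whether a longer propyl chain, or a morpholin-4-yl or dimethylamino end group, keeps the low numbers remains open.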